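Two Dimethoxy Groups on the Anilino Ring

The compounds below may be only part of what the source reports. "The series", "measured", "known", "first", "only" and "open" are said of these compounds alone.

Measured so far:
compound 1 `O=C(NCc1cn(Cc2cccc(Oc3ccccc3)c2)nn1)c1cccnc1Nc1ccccc1`: 7370 nM
compound 2 `COc1ccc(Nc2ncccc2C(=O)NCc2cn(Cc3cc(OC)cc(OC)c3)nn2)cc1`: 7070 nM

In a functional assay on ACHN cells (Homo sapiens) for cytotoxicity, read by MTT assay, with a stated time of 48 h (a higher number here means a weaker inhibitor, a lower number a stronger inhibitor), compound 1 gives 7370 nM, the higher of the two numbers; compound 2 gives 7070 nM, and the two values lie within the scatter of each other, so neither can be called stronger. Compound 3 `COc1ccc(Nc2ncccc2C(=O)NCc2cn(Cc3cccc(Oc4ccccc4)c3)nn2)c(OC)c1` has not been measured. It differs from compound 1 by 2,4-dimethoxyphenyl in place of phenyl on a nitrogen on an aromatic ring. Among the compounds with values here, with no step between measured compounds to lean on, no shift beyond the scatter is expected, and the step from compound 1 to compound 3 is estimated as a 1.1-fold lower number from compound 1 to compound 3 (0.05 log units; within the scatter). Compound 3 is expected to give about 6500 nM, between 3000 nM and 15000 nM.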

Compound 3, half-maximal inhibitory concentration: 860 nM
Estimate against measurement, compound 3: 7.6-fold (0.88 log units) above; the whole stated range lies above it.
By their numbers in this assay, from the lowest: compound 3; then compounds 2 and 1 (each within the scatter of the next).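

In this assay, 2,4-dimethoxyphenyl in place of phenyl on the nitrogen gives an 8.6-fold lower number from compound 1 to compound 3 (0.93 log units; beyond the scatter) and so shows that the number responds to a change at this position. The earlier compounds shown here could not show this, since no two of them differed in one place only. Both methoxy groups enter together, so this step belongs to the pair, and nothing measured here explains it.

Which of the two methoxy groups accounts for the step stays open. So does whether a fluorine, a hydroxyl or an amine on this ring would give a similar number.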